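The source may report more compounds than this note shows. Statements on the series, on what has been measured and on what is new or still open speak of the compounds shown alone.

Compounds measured so far:
compound 1, `CCCOC(=O)C1=C(C)NC(=O)NC1c1ccoc1`, 11%
compound 2, `CC1=C(C(=O)OCC(C)C)C(c2ccoc2)NC(=O)N1`, 16%
compound 3, `CCCC(=O)C1=C(C)NC(=O)NC1c1ccsc1`, 1%

All three were tested in an assay on membranes from HeLa cells for displacement of a labelled ligand from adenosine receptor A3 (Homo sapiens), read by scintillation counting, with a stated time of 180 min, tested at 1 uM; on this read-out lower numbers stand for less inhibition and higher numbers for more inhibition at the one concentration tested (going by the name of the read-out). Compound 1 gives 11% in this assay, and compound 2, which differs from it by methyl in place of hydrogen on a saturated chain carbon bound to two saturated chain carbons, gives 16%. The step between them, a number 5 percentage points higher from compound 1 to compound 2 (within the scatter), is within the scatter, so the change from hydrogen to methyl on that chain carbon made no difference that this assay can resolve. Compound 3 carries a different core, and the difference between the two cores is not broken down here. In this assay compound 3 gives 1%, a number that lies within the scatter of compound 1 but beyond the scatter of compound 2.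

Compound 4, `CC1=C(C(=O)CC(C)C)C(c2ccsc2)NC(=O)N1`, has not yet been measured. For the measured compounds named here, it differs from compound 3 by methyl in place of hydrogen on a saturated chain carbon bound to two saturated chain carbons, which is the same change, at the same kind of place, as the one that separates compound 1 from compound 2. Going by the values given here, the only guide to its size is that earlier step, a number 5 percentage points higher from compound 1 to compound 2 (within the scatter), which stayed within the scatter. Among the compounds with values here, on that basis the expected step is a number 4 percentage points higher from compound 3 to compound 4 (within the scatter), a small move of the same order as the one seen from compound 1 to compound 2. Compound 4 is therefore expected to give 5% in this assay. The estimated range for compound 4 runs from -3% to 15%.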

Compound 4, a percentage reported as inhibition, at one concentration (the size of the read-out at that concentration, not a potency): 14%
Compound 4: middle estimate off by 9 percentage points, on the low side, and the stated range covers the measured number.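

On the core of compound 3, methyl in place of hydrogen on a saturated chain carbon bound to two saturated chain carbons gives a number 13 percentage points higher from compound 3 to compound 4 (beyond the scatter) in this assay. Set beside the same change on the core of compound 1, the two steps cannot be told apart: the same change on two cores in this assay, a number 5 percentage points higher (within the scatter) from compound 1 to compound 2 and a number 13 percentage points higher (beyond the scatter) from compound 3 to compound 4, 8 percentage points apart, within the scatter of two such steps. For the compounds shown here, the result is thus compatible with a change that carries over between these two cores at a similar size, but although only the step on the core of compound 3 stands beyond the scatter, it does not show that the methyl counts for more on that core, and two pairs set no rule for any other core.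

The chains in the compounds shown end in propyl or isobutyl, so it remains open how a longer chain, a cyclopropyl group or a terminal amine would read out at this position. Since every number here is the size of the inhibition at one concentration, the compounds shown also leave open how the pairs would compare in potency.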